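The source may report more compounds than this note shows. Statements on the series, on what has been measured and on what is new or still open speak of the compounds shown alone.

Measured in a functional assay on HeLa cells (Homo sapiens) for cytotoxicity, read by MTT assay; on this read-out lower numbers stand for stronger inhibition and higher numbers for weaker inhibition:
- compound 1 `CC(C)=CC[C@@H](OC(=O)CCO)C1=CC(=O)c2c(O)ccc(O)c2C1=O` gives 67600 nM
- compound 2 `CC(C)=CC[C@@H](OC[C@@H](C)O)C1=CC(=O)c2c(O)ccc(O)c2C1=O` gives 22500 nM
- compound 3 `CC[C@](C)(O)CC(=O)O[C@H](CC=C(C)C)C1=CC(=O)c2c(O)ccc(O)c2C1=O` gives 30200 nM

Compound 3 sits with compound 2 at the lower end of these three numbers (a 1.3-fold higher number from compound 2 to compound 3 (0.13 log units; within the scatter)) and clear of compound 1 (a 2.2-fold lower number from compound 1 to compound 3 (0.35 log units; beyond the scatter)).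

The next structure is compound 4 `CCC(O)CO[C@H](CC=C(C)C)C1=CC(=O)c2c(O)ccc(O)c2C1=O`, and the change is 2-hydroxybutyl in place of (2-hydroxy-2-methylbutyl)carbonyl on an oxygen on a saturated carbon (in words, 2-hydroxybutyl in place of (2-hydroxy-2-methylbutyl)carbonyl on an oxygen on a saturated carbon).

The closest guide is compound 2, which has 2-hydroxypropyl on that oxygen. The exchange of that group for the carbonyl-bearing group of compound 3 gave only a small shift (a 1.3-fold higher number from compound 2 to compound 3 (0.13 log units; within the scatter)). The other exchange of this kind was modest (a 3.0-fold lower number from compound 1 to compound 2 (0.48 log units; beyond the scatter)), but it starts from compound 1, the outlying number of the three. A shift beyond the scatter is therefore not expected in this assay.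

The estimated change is a 1.3-fold lower number from compound 3 to compound 4 (0.10 log units; within the scatter) and would stay within the scatter. Compound 4 is estimated at 24000 nM, with an expected range of 11000 nM to 50000 nM.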

Compound 4, half-maximal inhibitory concentration: 28700 nM
Compound 4: the middle estimate sits 1.2-fold (0.08 log units) below what was measured; the range from low to high includes it.
By their numbers in this assay, from the lowest: compounds 2, 4 and 3 (each within the scatter of the next); then compound 1.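

In this assay, 2-hydroxybutyl in place of (2-hydroxy-2-methylbutyl)carbonyl on this oxygen stays within the scatter (a 1.1-fold lower number from compound 3 to compound 4 (0.02 log units; within the scatter)), so this exchange, which removes the carbonyl, leaves the number effectively unchanged. The 2-hydroxybutyl and 2-hydroxypropyl groups also cannot be separated, with 1-hydroxypropyl in place of 1-hydroxyethyl giving only a 1.3-fold higher number from compound 2 to compound 4 (0.11 log units; within the scatter). Only compound 1 stands apart (a 2.4-fold lower number from compound 1 to compound 4 (0.37 log units; beyond the scatter)), and the carbonyl alone does not mark that difference, as compound 3 also carries a carbonyl at this position but lies within the scatter of compound 2 and compound 4.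

An amine or a carboxylic acid on this oxygen, or a chain longer than 2-hydroxybutyl, remains an open test of whether this position can move the number further. No available evidence bears on the separation of compound 1 from the other three compounds.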